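A Longer Alkyl Chain Beside the Azide Group

A few compounds are considered here, and "the series" means these few. Any claim that something is new, unique, unknown or untested is made for them only; others in the source may bear on it.

Compound 2 `CCCCCCc1cc2c(=O)n(CCN=[N+]=[N-])cnc2s1` was tested in an ADME assay on MCF7 cells (Homo sapiens) for cytotoxicity, read by MTT assay, with a stated time of 11 days; a lower number here means a stronger inhibitor of growth, a higher number a weaker inhibitor of growth. In this assay compound 2 reaches only the limit of the assay, > 100 ug/mL, and gives no number. Compound 1 `CCCCCCCc1cc2c(=O)n(CC3CC3)cnc2s1` likewise shows only a limit in this assay, > 100 ug/mL. Both results sit at the limit of > 100 ug/mL in this assay, at which 2 of the 2 values shown sit. Compound 3 `CCCCCCCc1cc2c(=O)n(CCN=[N+]=[N-])cnc2s1` differs from compound 2 by methyl in place of hydrogen on a saturated chain carbon, six bonds along the chain from an aromatic carbon. Within the data shown here, with no measured step to draw on and both known results at a limit, no shift beyond the scatter is expected, a step that the limit leaves unreadable from compound 2 to compound 3. Compound 3 is therefore estimated at 150 ug/mL, between 50 ug/mL and 500 ug/mL, most likely again only a limit.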

Compound 3, concentration for 50% growth inhibition: > 100 ug/mL
Compound 3 ended at the assay's limit; the forecaster's own chance of this, stated with the estimate: 85%; the middle value lies beyond the limit too.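

No step can be read among compound 1, compound 2 and compound 3 in this assay, since each gives only a limit: the limit of > 100 ug/mL in this assay, at which 3 of the 3 values shown sit.

The compounds shown leave open whether either structural difference changes growth inhibition at all.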